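Hydroxamate side chains on the shared core: compound 2 to compound 3

The compounds below may be only part of what the source reports. "The series", "measured", "known", "first", "only" and "open" are said of these compounds alone.

compound 1 `CCOc1cc(C(C)(C)C)ccc1C1=NC(c2ccc(Cl)cc2)C(c2ccc(Cl)cc2)N1C(=O)N1CCN(Cc2ccc(C(=O)NO)cc2)CC1`: 3970 nM
compound 2 `CCOc1cc(C(C)(C)C)ccc1C1=NC(c2ccc(Cl)cc2)C(c2ccc(Cl)cc2)N1C(=O)N1CCN(CCCCC(=O)NO)CC1`: 9800 nM

For the measured compounds named here, in a functional assay on MCF7 cells (Homo sapiens) for antiproliferative activity, read by CCK-8 assay, with a stated time of 72 h (on this read-out higher numbers stand for weaker inhibition and lower numbers for stronger inhibition), compound 2 gives 9800 nM, the higher of the two numbers so far. The next structure is compound 3 `CCOc1cc(C(C)(C)C)ccc1C1=NC(c2ccc(Cl)cc2)C(c2ccc(Cl)cc2)N1C(=O)N1CCN(c2ncc(C(=O)NO)cn2)CC1`, with 5-(hydroxycarbamoyl)pyrimidin-2-yl in place of 4-(hydroxycarbamoyl)butyl on an amine nitrogen in a ring. Going by the values given here, one measured step bears on this change, a 2.5-fold higher number from compound 1 to compound 2 (0.39 log units; beyond the scatter), where an open chain replaced a group with an aromatic ring. Among the compounds with values here, that step is modest, and no measured compound carries the entering group, so the analogy is only partial. A modest move to a lower number is therefore expected in this assay, towards compound 1 at 3970 nM. The expected change is a 2.0-fold lower number from compound 2 to compound 3 (0.29 log units; within the scatter). For compound 3 the estimate is 5000 nM, with an expected range of 1700 nM to 14000 nM.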

Compound 3, half-maximal inhibitory concentration: 3460 nM
Compound 3: the middle estimate sits 1.4-fold (0.16 log units) above what was measured; the measured number falls inside the stated range.
By their numbers in this assay, from the lowest: compounds 3 and 1 (each within the scatter of the next); then compound 2.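

In this assay, 5-(hydroxycarbamoyl)pyrimidin-2-yl in place of 4-(hydroxycarbamoyl)butyl on the ring amine nitrogen gives a 2.8-fold lower number from compound 2 to compound 3 (0.45 log units; beyond the scatter) and so reverses the loss seen with the open chain. Set against 4-(hydroxycarbamoyl)benzyl, the same group gives a 1.1-fold lower number from compound 1 to compound 3 (0.06 log units; within the scatter) and thus does not separate from it, so among these three compounds both groups with an aromatic ring stand apart from the open chain, with no compound going against this. Nothing measured here accounts for these differences.

Still open, on these data alone, is whether a longer chain on this nitrogen would stay level with compound 2 or approach compound 1 and compound 3. Also open, as far as these compounds go, is how a carboxylic acid in place of the hydroxycarbamoyl group would read on the pyrimidine ring.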